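Amide aryl variation on the shared core: compound 3

The source may hold more compounds than are shown below. What is called first, only, known or untested is meant among the compounds shown, and "the series" means these compounds.

Compound 2 `O=C(Nc1ccc(Cl)c(-c2nnc3c(Cl)cccn23)c1)c1cccc(Cl)c1` carries a 3-chlorophenyl on the carbonyl carbon of the shared core. Among the compounds with values here, in a functional assay on T47D cells (Homo sapiens) for antiproliferative activity, read by MTT assay, with a stated time of 72 h (on this read-out lower numbers stand for stronger inhibition and higher numbers for weaker inhibition), compound 2 gives 30200 nM, the only plain number in the set so far. Compound 1 `Cc1nc(C(=O)Nc2ccc(Cl)c(-c3nnc4c(Cl)cccn34)c2)cs1` is known in this assay only as a limit, > 100000 nM, and the limit of > 100000 nM in this assay, at which 1 of the 2 values shown sits, marks that one of the two values shown sits there. Within the data shown here, the one measured step, an at least 3.3-fold lower number from compound 1 to compound 2 (0.51 log units; beyond the scatter), runs from a limit to a number, so its true size is open-ended.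

Compound 3 `O=C(Nc1ccc(Cl)c(-c2nnc3c(Cl)cccn23)c1)c1ccc(Cl)cc1Cl` differs from compound 2 at the same position: 2,4-dichlorophenyl in place of 3-chlorophenyl on a carbonyl carbon. Among the measured compounds shown here, no measured step concerns adding a second chlorine to an aryl group that already stands on the carbonyl; the single step on hand swaps a heteroaryl for a chlorophenyl and says nothing about the count or placement of chlorines. Without a bearing step, the expectation is a change within the scatter, with a wide band to either side. Compound 3 is therefore expected to give 25000 nM in this assay, between 8000 nM and 80000 nM, a step of a 1.2-fold lower number from compound 2 to compound 3 (0.08 log units; within the scatter).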

Compound 3, half-maximal inhibitory concentration: > 100000 nM
Compound 3: no number, only a limit (the forecaster's own chance of this, stated with the estimate: 20%); middle value at least 4.0-fold (0.60 log units) from the limit.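

With 2,4-dichlorophenyl in place of 3-chlorophenyl on the carbonyl carbon, this assay shows an at least 3.3-fold higher number from compound 2 to compound 3 (0.51 log units; beyond the scatter), so this position responds to a change within the chlorophenyl family and not only to the swap of a heteroaryl for a chlorophenyl. Compound 3 is known only as a limit, > 100000 nM. A chlorophenyl on the carbonyl carbon therefore does not by itself give a plain number, compound 2 remains the only compound with one, and the step between compound 1 and compound 3 cannot be read, with a limit at each end: the limit of > 100000 nM in this assay, at which 2 of the 3 values shown sit.

Since 2,4-dichlorophenyl and 3-chlorophenyl differ in both the count and the placement of chlorine, the compounds shown cannot separate the second chlorine from the changed pattern, and a 4-chlorophenyl or 2-chlorophenyl group on the carbonyl carbon would bear on that question. Also open, from the compounds shown here alone, is how this position responds to groups that carry no chlorine at all, such as an aminophenyl group or a phenyl group bearing a carboxylic acid.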